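The compounds below may be only part of what the source reports. "The series", "measured", "known", "first", "only" and "open" are said of these compounds alone.

Compound 3 `C#Cc1cc(C(F)(F)F)cc(C(F)(F)F)c1` is the point of departure. In an ADME assay for pharmacokinetics, read by HPLC, in phosphate buffer, with a stated time of 72 h, at pH 7.4, tested at 250 uM (on this read-out lower numbers stand for a shorter-lived compound and higher numbers for a longer-lived compound), compound 3 gives > 50 h, which is a limit of the assay rather than a number, the one described in the limit of > 50 h in this assay, at which 1 of the 3 values shown sits. Two other compounds carry the same core. In this assay compound 1 `C=CS(=O)(=O)c1cc(C(F)(F)F)cc(C(F)(F)F)c1` gives < 0.017 h, again a limit and not a number. In this assay compound 2 `O=C1C=CC(=O)N1c1cc(C(F)(F)F)cc(C(F)(F)F)c1` gives < 0.017 h, once more a limit and not a number. Those two readings are the ones gathered under (the limit of < 0.017 h in this assay, at which 2 of the 3 values shown sit). The measured steps run an at least 2900-fold higher number from compound 1 to compound 3 (3.46 log units; beyond the scatter) and an at least 2900-fold higher number from compound 2 to compound 3 (3.46 log units; beyond the scatter), both large, while a step that the two limits leave unreadable from compound 1 to compound 2 cannot be sized. Compound 4 `N#Cc1cc(C(F)(F)F)cc(C(F)(F)F)c1` differs from compound 3 by cyano in place of ethynyl on an aromatic carbon. Neither measured step touches this exchange; both replace a larger group with the ethynyl, so they give no direct guide, and compound 3 itself sits at a limit. He therefore expects no step beyond the scatter, a step that the limit leaves unreadable from compound 3 to compound 4, for compound 4. His estimate for compound 4 in this assay is 200 h, within 50 h to 1000 h, most likely reported again as a limit.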

Compound 4, half-life: > 50 h
Compound 4 was reported as a limit (the forecaster's own chance of this, stated with the estimate: 85%); the middle value lies beyond the limit too.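

With cyano in place of ethynyl, the position keeps its reading at the long-lived end of this assay, so a second group, this one with a nitrogen and a hydrogen-bond acceptor, joins compound 3 at the same limit: the limit of > 50 h in this assay, at which 2 of the 4 values shown sit.

Cyano in place of vinylsulfonyl gives an at least 2900-fold higher number from compound 1 to compound 4 (3.46 log units; beyond the scatter), and cyano in place of the five-membered ring group gives an at least 2900-fold higher number from compound 2 to compound 4 (3.46 log units; beyond the scatter), so the large gap at this position no longer rests on ethynyl alone. The step between ethynyl and cyano cannot be read, as both readings are limits.

As far as these compounds go, how far apart compound 3 and compound 4 truly lie stays open. From the compounds shown here alone, it is also open whether an amine, a carboxylic acid or a longer chain at this position on the shared core would stay at this limit.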